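Cyclopropylmethyl Replacing 4-Chlorophenyl: Cytotoxicity Notes

The source may hold more compounds than are shown below. What is called first, only, known or untested is meant among the compounds shown, and "the series" means these compounds.

Measured compounds:
compound 1, `CN1C(=O)C(C2=NS(=O)(=O)c3cc(NS(C)(=O)=O)ccc3N2)=C(O)C2CCCC21`, "not determined" (no result reported)
compound 2, `CS(=O)(=O)Nc1ccc2c(c1)S(=O)(=O)N=C(C1=C(O)C3CCCC3N(Cc3ccc(Cl)cc3)C1=O)N2`, > 10000 nM
compound 3, `CS(=O)(=O)Nc1ccc2c(c1)S(=O)(=O)N=C(C1=C(O)[C@H]3CCC[C@H]3N(CC3CC3)C1=O)N2`, > 33000 nM

In an ADME assay on Huh-7 cells (Homo sapiens) for cytotoxicity, with a stated time of 72 h (a higher number here means that more compound is tolerated, a lower number that less compound is tolerated), compound 1 gives "not determined" (no result reported). In this assay compound 2 reaches only > 10000 nM, which is a limit of the assay and not a number, namely (the limit of > 10000 nM in this assay, at which 1 of the 3 values shown sits). In this assay compound 3 likewise sits at a limit, > 33000 nM, namely (the limit of > 33000 nM in this assay, at which 1 of the 3 values shown sits). Compound 2 therefore stands with a limit only; one other value shown is also a limit, and the remaining entry carries no number.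

Compound 4 `CS(=O)(=O)Nc1ccc2c(c1)S(=O)(=O)N=C(C1=C(O)C3CCCC3N(CCC3CC3)C1=O)N2` differs from compound 2 by cyclopropylmethyl in place of 4-chlorophenyl on a saturated chain carbon bound to an amide-type nitrogen in a ring. Going by the values given here, no step between measured compounds is available, so the size of this change cannot be read from the data. Both limits point the same way, and compound 4 is expected to behave like them, with a step that the limit leaves unreadable from compound 2 to compound 4 that is expected to stay within the scatter. For compound 4 the estimate is 20000 nM, in the range 8000 nM to 40000 nM, most likely reported again only as a limit.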

Compound 4, half-maximal cytotoxic concentration: > 33000 nM
Compound 4 was reported as a limit (the forecaster's own chance of this, stated with the estimate: 80%); middle value at least 1.6-fold (0.21 log units) away from the limit.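

In this assay compound 4 gives > 33000 nM, a limit and not a number. Compound 2 gives > 10000 nM, also a limit. Going by these compounds alone, no step between compound 2 and compound 4 can be read from these limits. The compounds shown leave open where the half-maximal cytotoxic concentration of either compound actually lies.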